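A few compounds are considered here, and "the series" means these few. Any claim that something is new, unique, unknown or untested is made for them only; others in the source may bear on it.

Measured in a functional assay on NALM-6 cells (Homo sapiens) for cytotoxicity, with a stated time of 72 h; a higher number here means that more compound is needed for the effect, a lower number that less compound is needed; each value is a limit of the assay and not a number:
- Compound 1 `COc1ccc(/C=C/[C@@](C)(/C=C/c2ccc(O)c(C=O)c2)CCC=C(C)C)cc1`: > 43400 nM
- Compound 2 `CCOC(=O)/C=C/c1cc(/C=C/[C@](C)(/C=C/c2ccc(OC)cc2)CCC=C(C)C)ccc1O`: > 43400 nM
- Compound 3 `COc1ccc(/C=C/[C@@](C)(/C=C/c2ccc(O)cc2)CCC=C(C)C)cc1`: > 43400 nM

Compound 3 has no exact value, only the limit > 43400 nM. The whole set shares this reading: the limit of > 43400 nM in this assay, at which 3 of the 3 values shown sit.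

Compound 4 `CC(C)=CCC[C@@](C)(/C=C/c1ccccc1)/C=C/c1ccc(O)cc1` differs from compound 3 in one place: hydrogen in place of methoxy on an aromatic carbon. Hydrogen stands in place of methoxy on an aromatic carbon, so 4-methoxyphenyl becomes phenyl.

Three measured steps are available: a step that the two limits leave unreadable from compound 1 to compound 2, a step that the two limits leave unreadable from compound 1 to compound 3 and a step that the two limits leave unreadable from compound 2 to compound 3. Going by the values given here, none of them removes the methoxy group, and none has a readable size, so they offer no measured step to carry over. The expectation therefore rests on (the limit of > 43400 nM in this assay, at which 3 of the 3 values shown sit), which suggests that compound 4 will also stay at the limit in this assay, with no clear shift in either direction.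

The expected step is a step that the limit leaves unreadable from compound 3 to compound 4, which is no more than an estimate. For compound 4 the estimated value is 45000 nM, with an expected range from 15000 nM to 90000 nM.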

Compound 4, half-maximal effective concentration: > 43400 nM
Compound 4: only a limit was reported; the forecaster's own chance of this, stated with the estimate: 80%; the middle value does not contradict the limit.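

The step from compound 3 to compound 4, hydrogen in place of methoxy, cannot be read, as each compound gives only a limit and not a number in this assay. The compounds shown leave open which groups, if any, affect cytotoxicity, since all share one reading: the limit of > 43400 nM in this assay, at which 4 of the 4 values shown sit.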